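Ester variation on the core of compound 1

A few compounds are considered here, and "the series" means these few. Any claim that something is new, unique, unknown or untested is made for them only; others in the source may bear on it.

The series shares the core of compound 1 `NCc1ccc(C(=O)Nc2ccncc2F)cc1-c1cccc(C(=O)O)c1`. In an ADME assay on a cell-free system (plasma, Homo sapiens) for metabolic stability, read by LC-MS (a higher number here means that the compound lasts longer, a lower number that the compound disappears faster), compound 1 reaches the assay limit, > 2 h, which is a limit and not a number (the limit of > 2 h in this assay, at which 1 of the 3 values shown sits). Compound 2 `NCc1ccc(C(=O)Nc2ccncc2F)cc1-c1cccc(C(=O)Oc2ccccc2)c1` carries phenyl in place of hydrogen on an oxygen next to a carbonyl group, and in this assay compound 2 gives 0.117 h. This step, an at least 17-fold lower number from compound 1 to compound 2 (1.23 log units; beyond the scatter), is the only measured one. Among the compounds with values here, compound 3 `CCCOC(=O)c1cccc(-c2cc(C(=O)Nc3ccncc3)ccc2CN)c1` is a further ester, and in this assay compound 3 gives 0.3 h; no single-point step to compound 2 is defined, but its number stands above that of compound 2. Compound 2 thus holds the lowest of the two numbers recorded, with compound 3 the nearest.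

Compound 4 `NCc1ccc(C(=O)Nc2ccncc2F)cc1-c1cccc(C(=O)OCC2CCCCO2)c1` differs from compound 2 by (oxan-2-yl)methyl in place of phenyl on an oxygen next to a carbonyl group. Within the data shown here, the only measured step also concerns the oxygen next to a carbonyl group, so a change here is expected to move the number again, plausibly upward, as compound 3 with 0.3 h also sits above compound 2. For compound 4 the step is expected to be a 3.4-fold higher number from compound 2 to compound 4 (0.53 log units; beyond the scatter). The estimate for compound 4 is 0.4 h, with a range from 0.15 h to 1.1 h.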

Compound 4, half-life: 0.117 h
For compound 4 the middle estimate is 3.4-fold (0.53 log units) above the measured one; measured number outside the range, below it.
By their numbers in this assay, from the lowest: compounds 2 and 4 (each within the scatter of the next); then compound 3. At a limit, above all of these: compound 1.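

Phenyl and (oxan-2-yl)methyl on an oxygen next to a carbonyl group read alike in this assay, with no change at the digits printed from compound 2 to compound 4 (within the scatter), although the entering group brings a non-aromatic ring with 1 hetero atom and a hydrogen-bond acceptor that phenyl lacks. In place of hydrogen on the same oxygen, (oxan-2-yl)methyl gives an at least 17-fold lower number from compound 1 to compound 4 (1.23 log units; beyond the scatter), so a second, quite different ester on the core of compound 1 repeats the large step seen with phenyl. This step rests on a limit, not a number, for compound 1: the limit of > 2 h in this assay, at which 1 of the 4 values shown sits.

Open, from the compounds shown here alone, is whether a chain carrying an amine, or a longer chain, on this oxygen would read differently from compound 2 and compound 4. Also open, going by these compounds, is where an amide in place of the ester would stand in this assay.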